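A few compounds are considered here, and "the series" means these few. Any claim that something is new, unique, unknown or untested is made for them only; others in the source may bear on it.

Working notes on the series, tested in an ADME assay on HCT-116 cells (Homo sapiens) for cytotoxicity; on this read-out higher numbers stand for lower toxicity in this test and lower numbers for higher toxicity in this test. Among the compounds with values here, compound 1 `COc1ccc(-n2c(Cc3ccccc3)nnc2SCC(=O)NNC(=O)c2ccccc2O)cc1` is the first point on the shared core. In this assay compound 1 reaches only the limit of the assay, > 20000 nM, so no number is known for it. Compound 2 `O=C(CSc1nnc(-c2ccc(Cl)cc2)n1-c1ccccc1)NNC(=O)c1ccccc1O` carries a 4-chlorophenyl on the shared core. In this assay compound 2 likewise gives only a limit, > 20000 nM, and not a number. Where compound 2 stands is thus only at the edge of what the assay reports: the limit of > 20000 nM in this assay, at which 2 of the 2 values shown sit. Within the data shown here, no step between two measured compounds can be read, since no measured pair differs in one place.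

Compound 3 `COc1ccc(-c2nnc(SCC(=O)NNC(=O)c3ccccc3O)n2-c2ccccc2)cc1OC` is not yet measured. It differs from compound 2 in one place: 3,4-dimethoxyphenyl in place of 4-chlorophenyl on an aromatic carbon. With both measured compounds sitting at the limit, no direction can be drawn from the data, and the expected step in this assay is a step that the limit leaves unreadable from compound 2 to compound 3, none beyond the scatter. Compound 3 is expected to give 25000 nM in this assay, with a range from 12000 nM to 50000 nM, most likely again only as a limit.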

Compound 3, half-maximal cytotoxic concentration: > 20000 nM
Compound 3: a limit, no number; the forecaster's own chance of this, stated with the estimate: 80%; the middle value lies beyond the limit too.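

In this assay compound 3 gives > 20000 nM, which is a limit and not a number. No step can be read from compound 2 to compound 3, since both sit at the same edge of the read-out: the limit of > 20000 nM in this assay, at which 3 of the 3 values shown sit.

The compounds shown leave open whether any change on the shared core gives a measurable half-maximal cytotoxic concentration in this assay.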